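Series notes: cyano in place of hydrogen on compound 1

The compounds below may be only part of what the source reports. "The series", "measured", "known", "first", "only" and "open" are said of these compounds alone.

Measured so far:
compound 1, `C(=C1\CCN=C1c1cccnc1)\c1ccccc1`, 41.3%
compound 2, `COc1ccccc1/C=C1\CCN=C1c1cccnc1`, 49.5%

In an assay for displacement of a labelled ligand from Nicotinic acetylcholine receptor alpha8 subunit (Periplaneta americana), read by scintillation counting, with a stated time of 2 h, at 24 degrees C, tested at 10 uM (on this read-out higher numbers stand for more inhibition at the one concentration tested (going by the name of the read-out) and lower numbers for less inhibition), compound 1 stands within the scatter of compound 2, which gives 49.5%; the step of a number 8.2 percentage points higher from compound 1 to compound 2 (within the scatter) separates nothing. Compound 3, `N#Cc1ccc(/C=C2\CCN=C2c2cccnc2)cc1`, carries the change (cyano in place of hydrogen on an aromatic carbon). Among the measured compounds shown here, the only step in hand, methoxy in place of hydrogen on an aromatic carbon, lies within the scatter, and no step with a cyano group has been measured, so no shift beyond the scatter in this assay is expected. The expected step is a number 3.7 percentage points higher from compound 1 to compound 3 (within the scatter). Compound 3 is therefore estimated at 45%, between 25% and 65%.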

Compound 3, a percentage reported as inhibition, at one concentration (the size of the read-out at that concentration, not a potency): 31.4%
The estimate for compound 3 lay 13.6 percentage points above the measured number; measured number inside the range.
By their numbers in this assay, from the lowest: compounds 3, 1 and 2 (each within the scatter of the next, the first and the last beyond it).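

In this assay, cyano on an aromatic carbon, para to a large group, gives a number 9.9 percentage points lower from compound 1 to compound 3 (within the scatter) and so stays inside the scatter. Among the compounds shown here, this is the first reading for a cyano group on the series, and at this position it leaves the number of compound 1 unresolved from that of compound 3. No measurement on hand speaks to the origin of this step. Still open, going by these compounds, is whether an amine or a carboxylic acid at this same position would produce a step beyond the scatter.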